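Lengthening a benzyl chain on the urea nitrogen

A few compounds are considered here, and "the series" means these few. Any claim that something is new, unique, unknown or untested is made for them only; others in the source may bear on it.

Three compounds share one core and differ only in the group carried on an amide-type nitrogen. Compound 1 `CSc1cc(C)nc(SC)c1NC(=O)N(Cc1ccc(Oc2ccc(F)cc2)cc1)C1CCCCC1` carries a cyclohexyl there and, in an assay for inhibition of acyl-CoA:cholesterol acyltransferase (Oryctolagus cuniculus), using microsomes (a higher number here means a weaker inhibitor, a lower number a stronger inhibitor), compound 1 gives 23 nM. Compound 2 `CSc1cc(C)nc(SC)c1NC(=O)N(Cc1ccc(Oc2ccc(F)cc2)cc1)C1CCOCC1` carries an oxan-4-yl instead, and in this assay compound 2 gives 46 nM; the step of a 2.0-fold higher number from compound 1 to compound 2 (0.30 log units; within the scatter) stays within the scatter. Compound 3 `CSc1cc(C)nc(SC)c1NC(=O)N(Cc1ccccc1)Cc1ccc(Oc2ccc(F)cc2)cc1` carries a benzyl, and in this assay compound 3 gives 9.1 nM, the lowest of the three numbers. The steps of a 2.5-fold lower number from compound 1 to compound 3 (0.40 log units; beyond the scatter) and a 5.1-fold lower number from compound 2 to compound 3 (0.70 log units; beyond the scatter) are both beyond the scatter, so the benzyl-bearing compound 3 is the strongest inhibitor measured so far.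

Compound 4 `CSc1cc(C)nc(SC)c1NC(=O)N(CCCc1ccccc1)Cc1ccc(Oc2ccc(F)cc2)cc1` is not yet measured. It differs from compound 3 by phenethyl in place of phenyl on a saturated chain carbon bound to an amide-type nitrogen. Among the measured compounds shown here, none of the measured steps changes the length of this chain; they only exchange the whole group on the nitrogen and move the number by modest amounts. The expectation for a 1.6-fold higher number from compound 3 to compound 4 (0.22 log units; within the scatter) is therefore a small change, if any, in either direction. Compound 4 is estimated at 15 nM in this assay, with a range from 5 nM to 45 nM.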

Compound 4, half-maximal inhibitory concentration: 28 nM
Beside the measured number, compound 4's estimate is 1.9-fold (0.27 log units) below it; low and high end bracket the measured number.
By their numbers in this assay, from the lowest: compound 3; then compounds 1, 4 and 2 (each within the scatter of the next).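

Lengthening benzyl to 3-phenylpropyl keeps the phenyl ring and changes only the chain that carries it, and in this assay this gives a 3.1-fold higher number from compound 3 to compound 4 (0.49 log units; beyond the scatter), a modest loss of inhibition. The earlier steps shown here exchanged the whole group on the nitrogen, so they could not show that the number responds to chain length alone. With the longer chain, the advantage seen with benzyl is no longer apparent: a 1.2-fold higher number from compound 1 to compound 4 (0.09 log units; within the scatter) and a 1.6-fold lower number from compound 2 to compound 4 (0.22 log units; within the scatter) both stay within the scatter, so 3-phenylpropyl cannot be told apart from cyclohexyl or oxan-4-yl, and a phenyl ring on the chain is not enough by itself to match compound 3. No measurement at hand explains why the longer chain gives the higher number.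

The compounds shown leave open what a 2-phenylethyl group on this nitrogen would give, and so whether the number rises steadily with chain length or jumps at one particular length. They also leave open whether a longer chain such as 4-phenylbutyl, or a chain ending in an amine instead of phenyl, would move the number further.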